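Series notes: a second chloro on the aryl of compound 3

The source may report more compounds than this note shows. Statements on the series, on what has been measured and on what is new or still open speak of the compounds shown alone.

Measured in a functional assay (aorta) with Rattus norvegicus as the target; on this read-out lower numbers stand for stronger inhibition and higher numbers for weaker inhibition:
- compound 1, `CC1(C)Oc2ccc(C#N)cc2[C@@H](NC(=O)Nc2ccccn2)[C@@H]1O`: 440 nM
- compound 2, `COC(=O)c1cc2ccccc2n1[C@@H]1c2cc(C#N)ccc2OC(C)(C)[C@H]1O`: 33100 nM
- compound 3, `CC1(C)Oc2ccc(C#N)cc2[C@@H](/N=C(\NC#N)Nc2cccc(Cl)c2)[C@@H]1O`: 600 nM

Compound 3 holds the second highest of the three numbers. Its nearest neighbour is compound 1, whose number is lower by a margin that lies within the scatter, so the two cannot be ordered. Compound 2 stands far above both, beyond the scatter, and is the only one of the three that is clearly weaker in this assay.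

Compound 4, `CC1(C)Oc2ccc(C#N)cc2[C@@H](/N=C(\NC#N)Nc2ccc(Cl)c(Cl)c2)[C@@H]1O`, is not yet measured. It differs from compound 3 in one place: chloro in place of hydrogen on an aromatic carbon. The aryl goes from 3-chlorophenyl to 3,4-dichlorophenyl.

Going by the values given here, no pair of measured compounds in this set differs in a single place, so there is no measured step to lean on. The expected step from compound 3 to compound 4 in this assay is a 1.5-fold lower number from compound 3 to compound 4 (0.18 log units; within the scatter), a change of no size beyond the scatter, perhaps leaning towards a lower number. For compound 4 the estimate in this assay is 400 nM, within a range of 150 nM to 1200 nM.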

Compound 4, half-maximal inhibitory concentration: 4600 nM
For compound 4 the middle estimate is 12-fold (1.06 log units) below the measured one; the measured number lies above the stated range.
By their numbers in this assay, from the lowest: compounds 1 and 3 (each within the scatter of the next); then compound 4; then compound 2.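

In this assay, the change from 3-chlorophenyl to 3,4-dichlorophenyl gives a 7.7-fold higher number from compound 3 to compound 4 (0.88 log units; beyond the scatter). Going by these compounds alone, this is the first single-place step, and it shows that the aromatic carbon para to the large group does not accept a chloro freely when it is ortho to a chloro group, since inhibition is weaker in compound 4 than in compound 3. No measurement here accounts for this step.

On these data alone, whether the weakening belongs to chloro itself or would also follow from fluoro, methyl or methoxy on this carbon remains open. Also open, as far as these compounds go, is whether the same addition would cost as much on an unsubstituted phenyl, without the first chloro.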